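Swapping the halogenated phenyl ring in a trimethoxyphenyl triazole series

The source may report more compounds than this note shows. Statements on the series, on what has been measured and on what is new or still open speak of the compounds shown alone.

Measured compounds:
- Compound 1, `COc1cc(-c2nnc(SCC(=O)c3ccc(Cl)cc3)n2N)cc(OC)c1OC`: > 100000 nM
- Compound 2, `COc1cc(-c2nnc(SCC(=O)c3ccc(Br)cc3)n2N)cc(OC)c1OC`: > 100000 nM
- Compound 3, `COc1cc(-c2nnc(SCC(=O)c3cccc(Br)c3)n2N)cc(OC)c1OC`: > 100000 nM

Three compounds share one core and differ only in the halogenated phenyl ring attached to the carbonyl carbon. In a functional assay on PC-3 cells (Homo sapiens) for antiproliferative activity, read by MTT assay, with a stated time of 48 h (on this read-out higher numbers stand for weaker inhibition and lower numbers for stronger inhibition), compound 1 reaches only the limit of the assay, > 100000 nM, and not a number. Compound 2 likewise gives only a limit, > 100000 nM. Compound 3 also stops at a limit, > 100000 nM. Because of this, the steps a step that the two limits leave unreadable from compound 1 to compound 2, a step that the two limits leave unreadable from compound 1 to compound 3 and a step that the two limits leave unreadable from compound 2 to compound 3 cannot be read for size or direction: the limit of > 100000 nM in this assay, at which 3 of the 3 values shown sit.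

Compound 4, `COc1cc(-c2nnc(SCC(=O)c3ccc(F)c(F)c3)n2N)cc(OC)c1OC`, is the next member. It differs from compound 2 as follows: 3,4-difluorophenyl in place of 4-bromophenyl on a carbonyl carbon. Going by the values given here, no measured step informs this change, since every comparison so far is hidden by the limit. The only grounds for an expectation are that compound 2 sits at > 100000 nM and that two further ring variations left the read-out unchanged at the limit. Compound 4 is therefore expected to behave similarly, with a step that the limit leaves unreadable from compound 2 to compound 4. The estimate for compound 4 in this assay is 150000 nM, within 40000 nM to 600000 nM, most probably reported again only as a limit.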

Compound 4, half-maximal inhibitory concentration: > 100000 nM
Compound 4 gave a limit, no number (the forecaster's own chance of this, stated with the estimate: 80%); the middle value lies beyond the limit too.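

In this assay compound 4 gives only the limit > 100000 nM and no number, and its steps from compound 1, compound 2 and compound 3 cannot be read, because all four stop at the same limit: the limit of > 100000 nM in this assay, at which 4 of the 4 values shown sit.

Whether changing the halogenated phenyl ring affects activity at all stays open, as none of these compounds gives a number to compare.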